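This account rests on a few compounds, and the source may have more. Where it says the series, first, only, none or still open, it means among the compounds named here.

Of the compounds shown here, three sharing one core have been measured in a functional assay on BT-474 cells (Homo sapiens) for inhibition, read by MTT assay, with a stated time of 5 days (a lower number here means a stronger inhibitor, a higher number a weaker inhibitor), and they differ only in the substituted phenyl group on a saturated chain carbon bound to a nitrogen on an aromatic ring. Compound 2 `Cc1cc(Nc2nc(NCc3cccc(Cl)c3)nc3[nH]ncc23)n[nH]1` gives 12900 nM, which puts it at the high end of the numbers, level with compound 1 `Cc1cc(Nc2nc(NCc3ccccc3Br)nc3[nH]ncc23)n[nH]1` at 10100 nM. The two cannot be told apart, since the difference is a 1.3-fold higher number from compound 1 to compound 2 (0.11 log units; within the scatter). Compound 3 `Cc1cc(Nc2nc(NCc3ccc(Br)cc3)nc3[nH]ncc23)n[nH]1` gives 4110 nM, and it is the only one that stands clear of the others.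

The next compound to test is compound 4 `Cc1cc(Nc2nc(NCc3ccc(F)cc3F)nc3[nH]ncc23)n[nH]1`, which changes compound 2 in that same place: 2,4-difluorophenyl in place of 3-chlorophenyl on a saturated chain carbon bound to a nitrogen on an aromatic ring. For the measured compounds named here, three measured steps bear on this swap, all of them exchanges of one phenyl group for another. Besides the step above, there is a 2.5-fold lower number from compound 1 to compound 3 (0.39 log units; beyond the scatter) and also a 3.1-fold lower number from compound 2 to compound 3 (0.50 log units; beyond the scatter). Going by the values given here, none of the measured compounds carries fluorine, so these steps are only a loose guide. The name 2,4-difluorophenyl shares its numbers with both bromophenyl groups, and the two measured values for those groups, 10100 nM for compound 1 and 4110 nM for compound 3, both lie under the value of compound 2.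

A modest move to a lower number is therefore expected, a 2.2-fold lower number from compound 2 to compound 4 (0.33 log units; beyond the scatter). For compound 4 the estimated value is 6000 nM, with an expected range of 2500 nM to 14000 nM.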

Compound 4, half-maximal inhibitory concentration: 3220 nM
For compound 4 the middle estimate is 1.9-fold (0.27 log units) above the measured one, and the stated range covers the measured number.
By their numbers in this assay, from the lowest: compounds 4 and 3 (each within the scatter of the next); then compounds 1 and 2 (each within the scatter of the next).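

In this assay, for the compounds shown here, the 2,4-difluorophenyl group joins the low end of the series, with a 4.0-fold lower number from compound 2 to compound 4 (0.60 log units; beyond the scatter) and a 3.1-fold lower number from compound 1 to compound 4 (0.50 log units; beyond the scatter) showing that compound 3 is no longer the only compound clear of the other two. Compound 3 and compound 4 cannot be told apart, given a 1.3-fold lower number from compound 3 to compound 4 (0.11 log units; within the scatter) even though one group carries bromine and the other fluorine, so this place tolerates more than one halogen arrangement at the low end. Among these four compounds, the two groups at the low end, 4-bromophenyl and 2,4-difluorophenyl, both have a 4 in their names, while 2-bromophenyl and 3-chlorophenyl at the high end do not, and no compound shown goes against this, although four compounds are too few to establish a rule.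

Still open, as far as these compounds go, is whether this link to the 4 in the name holds beyond halogens, for example with 4-methoxyphenyl or 4-aminophenyl on a saturated chain carbon bound to a nitrogen on an aromatic ring. Nothing available here explains why these phenyl groups give different numbers.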